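This account rests on a few compounds, and the source may have more. Where it says the series, first, only, none or still open, it means among the compounds named here.

Working notes on the series, step from compound 3 to compound 4.

Compound 3 `Nc1scc(CN2CCN(c3ccc(OC(F)(F)F)cc3)CC2)c1C(=O)c1ccc(Cl)cc1` stands lowest of the three numbers in hand. In a functional assay on CHO cells with adenosine receptor A1 (Homo sapiens) as the target, read by cAMP accumulation and immunoassay, with a stated time of 6 min, tested at 1 uM (on this read-out lower numbers stand for a stronger effect and higher numbers for a weaker effect at the one concentration tested), compound 3 gives -51%. Compound 1 `COc1ccc(N2CCN(Cc3csc(N)c3C(=O)c3ccc(Cl)cc3)CC2)cc1` gives -15%, and compound 2 `Nc1scc(CN2CCN(c3ccc([N+](=O)[O-])cc3)CC2)c1C(=O)c1ccc(Cl)cc1` gives -8.3%; the step of a number 6.7 percentage points higher from compound 1 to compound 2 (within the scatter) is within the scatter, so these two are not ordered against each other. What sets compound 3 apart are the steps of a number 36 percentage points lower from compound 1 to compound 3 (beyond the scatter) and a number 42.7 percentage points lower from compound 2 to compound 3 (beyond the scatter), both large and both made by changing the group on the amine nitrogen in the ring.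

Compound 4 `Nc1scc(CN2CCN(c3ccncc3)CC2)c1C(=O)c1ccc(Cl)cc1` is not yet measured. The change is pyridin-4-yl in place of 4-(trifluoromethoxy)phenyl on an amine nitrogen in a ring. The two large steps above bear on it directly, since they show that the read-out in this assay moves strongly with what sits on that ring nitrogen; neither of them tests a ring with a hetero atom there, so the direction of the new step is read only off the spread of the three values. Because compound 1 and compound 2 lie well above compound 3 by a number 36 percentage points lower from compound 1 to compound 3 (beyond the scatter) and a number 42.7 percentage points lower from compound 2 to compound 3 (beyond the scatter), the expectation is that compound 4 moves back toward their level, an upward step estimated as a number 36 percentage points higher from compound 3 to compound 4 (beyond the scatter). For compound 4 the estimate in this assay is -15%, expected to fall between -40% and 5%.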

Compound 4, a percentage reported as activity, at one concentration (the size of the read-out at that concentration, not a potency): -8.3%
Compound 4: the middle estimate sits 6.7 percentage points below what was measured, and the stated range covers the measured number.
By their numbers in this assay, from the lowest: compound 3; then compounds 1, 2 and 4 (each within the scatter of the next).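

Working from the new step, a number 42.7 percentage points higher from compound 3 to compound 4 (beyond the scatter) in this assay shows that a six-membered aromatic ring on the amine nitrogen in a ring does not by itself carry the low number of compound 3, which remains the only compound whose steps to all three others lie beyond the scatter. Pyridin-4-yl is also the first group at this position with a hetero atom in the ring, and it does not separate from the 4-nitrophenyl or 4-methoxyphenyl groups: the comparisons no change at the digits printed from compound 2 to compound 4 (within the scatter) and a number 6.7 percentage points higher from compound 1 to compound 4 (within the scatter) leave compounds 1, 2 and 4 unordered. Among the four groups tested here, 4-(trifluoromethoxy)phenyl alone stands apart, so this change removes that separation rather than adding a new level.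

The compounds shown leave open how a 4-chlorophenyl group, a cyclohexyl ring or a plain methyl group on that ring nitrogen would read, and so whether the low number belongs to trifluoromethoxy specifically. No measurement at hand accounts for why compound 3 stands apart from the other three.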